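The source may hold more compounds than are shown below. What is called first, only, known or untested is meant among the compounds shown, and "the series" means these compounds.

In a physicochemical assay for solubility, read by spectrophotometry, in phosphate buffer, with a stated time of 18 h, at pH 7.4 (on this read-out lower numbers stand for lower solubility and higher numbers for higher solubility), the measured compounds stand as follows.

- Compound 1 `CCCc1ccc(-c2nc3c(c(C)nn3-c3ccccc3)c(-c3ccccc3O)c2C#N)cc1` gives 6500 nM
- Compound 2 `Cc1nn(-c2ccccc2)c2nc(-c3ccc(Cl)cc3)c(C#N)c(-c3ccccc3O)c12` gives 3800 nM
- Compound 3 `Cc1nn(-c2ccccc2)c2nc(-c3ccc(I)cc3)c(C#N)c(-c3ccccc3O)c12` gives 1500 nM

Compound 3 is the lowest of the three. Compound 4 `Cc1nn(-c2ccccc2)c2nc(-c3ccc([N+](=O)[O-])cc3)c(C#N)c(-c3ccccc3O)c12` is not yet measured and carries nitro in place of iodo on an aromatic carbon in this comparison. Three measured steps change the group at this same place: there is a 1.7-fold lower number from compound 1 to compound 2 (0.23 log units; within the scatter) as well as a 4.3-fold lower number from compound 1 to compound 3 (0.64 log units; beyond the scatter) and a 2.5-fold lower number from compound 2 to compound 3 (0.40 log units; beyond the scatter) in this set. None of them involves nitro, so they indicate a likely size but no firm direction. Since compound 3 holds the lowest number at 1500 nM among these compounds, a small rise is expected, probably within the scatter. The expected change is a 1.5-fold higher number from compound 3 to compound 4 (0.19 log units; within the scatter) on this estimate. For compound 4 the estimated value is 2300 nM with an expected range of 800 nM to 6000 nM in this assay overall.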

Compound 4, solubility: 6000 nM
For compound 4 the middle estimate is 2.6-fold (0.42 log units) below the measured one, within the range that was stated.
By their numbers in this assay, from the lowest: compound 3; then compounds 2, 4 and 1 (each within the scatter of the next).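

In this assay, nitro in place of iodo gives a 4.0-fold higher number from compound 3 to compound 4 (0.60 log units; beyond the scatter), so the low number with iodo is not shared by the other groups at this place. Nitro in place of chloro gives a 1.6-fold higher number from compound 2 to compound 4 (0.20 log units; within the scatter) and nitro in place of propyl gives a 1.1-fold lower number from compound 1 to compound 4 (0.03 log units; within the scatter), both within the scatter, which leaves iodo as the only one of the four groups set apart. Nothing shown accounts for this. Going by these compounds, it remains open whether an amine or a carboxylic acid at this place would stay with nitro, chloro and propyl or stand apart as iodo does.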